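Taking the chloro off compound 2

The source may report more compounds than this note shows. Statements on the series, on what has been measured and on what is new or still open speak of the compounds shown alone.

Compounds measured so far in a functional assay on L02 cells (Homo sapiens) for inhibition (on this read-out higher numbers stand for weaker inhibition and lower numbers for stronger inhibition), are these
Compound 1 `CCN(CC)CCNC(=O)CC(CC(=O)N(CC)C1Cc2ccccc2C1)c1ccc(Cl)cc1` gives 78400 nM as its value
Compound 2 `CCNCCNC(=O)CC(CC(=O)N(CC)C1Cc2ccccc2C1)c1ccc(Cl)cc1` gives 66200 nM as its value

Compound 2 has a single measured neighbour, and the two numbers cannot be ranked. It differs by hydrogen in place of ethyl on an amine nitrogen, and the step of a 1.2-fold lower number from compound 1 to compound 2 (0.07 log units; within the scatter) stays within the scatter.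

Compound 3 `CCNCCNC(=O)CC(CC(=O)N(CC)C1Cc2ccccc2C1)c1ccccc1` keeps the rest of compound 2 but has hydrogen in place of chloro on an aromatic carbon, para to a large group, so 4-chlorophenyl becomes phenyl. The counted change hydrogen in place of chloro on an aromatic carbon is the whole difference.

Among the compounds with values here, the one measured step lies at another place in the molecule, so it bears only indirectly, and no measured pair tests the chloro. A small shift in this assay is therefore expected, perhaps toward a higher number and hardly beyond the scatter. The expected step is a 1.4-fold higher number from compound 2 to compound 3 (0.13 log units; within the scatter) in size. For compound 3 the estimated value is 90000 nM (40000 nM to 180000 nM).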

Compound 3, half-maximal inhibitory concentration: > 100000 nM
Compound 3: no number, only a limit (the forecaster's own chance of this, stated with the estimate: 20%); middle value at least 1.1-fold (0.04 log units) away from the limit.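

In this assay, within the data shown here, the aromatic position that carries chloro is now tested directly for the first time, since the only earlier step lay on an amine nitrogen. Replacing chloro with hydrogen, which turns 4-chlorophenyl into phenyl, gives an at least 1.5-fold higher number from compound 2 to compound 3 (0.17 log units; that floor lies within the scatter). The value of compound 3 is a limit and not a number, so this step has a floor but no known upper end: the limit of > 100000 nM in this assay, at which 1 of the 3 values shown sits.

Taking the chloro away therefore brings no lower number, but because the floor of the step lies within the scatter, the pair does not establish that chloro contributes to inhibition in this assay; the true size of the step could be small or much larger.

The compounds shown leave open whether another group at this place, such as fluoro, bromo or methoxy, would give a lower number than chloro does. They also leave open whether the same change from 4-chlorophenyl to phenyl would behave alike on compound 1, with its diethylamino end, or with a primary amine at that end of the chain.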